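Three inactive triazole amides and a fluorophenyl analogue

The compounds below may be only part of what the source reports. "The series", "measured", "known", "first", "only" and "open" are said of these compounds alone.

Compound 1 `C#Cc1ccc(-c2cn(CC(=O)Nc3cc(C)on3)nn2)cc1` gives > 30000 nM in a functional assay on BMDM cells (Mus musculus, strain C57BL/6) for inhibition, with a stated time of 2 days (on this read-out higher numbers stand for weaker inhibition and lower numbers for stronger inhibition), which is a limit of the assay.
Compound 2 `Cc1cc(NC(=O)Cn2cc(-c3ccccc3Cl)nn2)no1` gives > 30000 nM in this assay, again a limit.
Compound 3 `Cc1cc(NC(=O)Cn2cc(-c3cccc(Cl)c3)nn2)no1` gives > 30000 nM in this assay, also a limit.

Compound 3 therefore stands only at a limit, as do the two other values shown (the limit of > 30000 nM in this assay, at which 3 of the 3 values shown sit). For the measured compounds named here, the one measured step, a step that the two limits leave unreadable from compound 2 to compound 3, cannot be read because both ends sit at that limit. The next compound, compound 4 `Cc1cc(NC(=O)Cn2cc(-c3ccc(F)cc3)nn2)no1`, differs from compound 3 by 4-fluorophenyl in place of 3-chlorophenyl on an aromatic carbon. Going by the values given here, no measured step bears readably on this change, so the expected step that the limit leaves unreadable from compound 3 to compound 4 is none beyond the scatter. Compound 4 is therefore expected to give 40000 nM, within a range of 15000 nM to 100000 nM, most probably reported once more only as a limit.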

Compound 4, half-maximal inhibitory concentration: > 30000 nM
Compound 4: only a limit was reported (the forecaster's own chance of this, stated with the estimate: 85%); the middle value is on the limit's open side.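

For the compounds shown here, compound 4 also stands only at a limit, so no step from compound 1, compound 2 or compound 3 to compound 4 can be read: the limit of > 30000 nM in this assay, at which 4 of the 4 values shown sit. The compounds shown leave open which change to the shared core, if any, would give a measurable value in this assay.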